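The source may hold more compounds than are shown below. What is called first, only, known or untested is meant among the compounds shown, and "the series" means these compounds.

Measured so far:
Compound 1 `CC(C)C(c1ncco1)c1ccc(-c2ccc3cccc(F)c3c2)[nH]c1=O` — 24 nM
Compound 2 `CCC(CC)(c1nnc[nH]1)c1ccc(-c2ccc3cccc(F)c3c2)[nH]c1=O` — 19 nM

In an assay on CHO cells for displacement of a labelled ligand from prostaglandin E2 receptor EP3 subtype (Homo sapiens), read by radioligand binding (a higher number here means a weaker inhibitor, a lower number a stronger inhibitor), compound 1 gives 24 nM, the higher of the two numbers; compound 2 gives 19 nM, and this gap lies within the scatter, so neither compound can be called the stronger inhibitor. Compound 3 `CC(C)C(Cc1noc(=O)[nH]1)c1ccc(-c2ccc3cccc(F)c3c2)[nH]c1=O` is not yet measured. It differs from compound 1 by a group of 7 heavy atoms (3 carbon, 2 nitrogen, 2 oxygen; one five-membered aromatic ring with 3 hetero atoms) in place of a group of 5 heavy atoms (3 carbon, 1 nitrogen, 1 oxygen; one five-membered aromatic ring with 2 hetero atoms), on a saturated chain carbon bound to an aromatic carbon and a saturated chain carbon. Within the data shown here, no measured pair shows a comparable change, so the expected step is uncertain; the estimate is a 1.3-fold higher number from compound 1 to compound 3 (0.10 log units; within the scatter), a modest shift that could fall either way. Compound 3 is expected to give 30 nM, within 8 nM to 120 nM.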

Compound 3, inhibition constant: 34 nM
Compound 3: the middle estimate sits 1.1-fold (0.05 log units) below what was measured; low and high end bracket the measured number.
By their numbers in this assay, from the lowest: compounds 2, 1 and 3 (each within the scatter of the next).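

In this assay, replacing the 1,3-oxazol-2-yl group on this saturated chain carbon with the larger group bearing a five-membered aromatic ring with 3 hetero atoms gives a 1.4-fold higher number from compound 1 to compound 3 (0.15 log units; within the scatter), so for this pair the added heavy atoms and the hydrogen-bond donor leave the number unchanged within the scatter. No available evidence explains this result. On these data alone, whether a carboxylic acid or an amine at this carbon would give a similar number stays open, as does whether a plain longer chain without a ring would.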